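Cytotoxicity of Hydroxamate Analogues Bearing an Aromatic Hydroxy Group

The source may hold more compounds than are shown below. What is called first, only, known or untested is meant among the compounds shown, and "the series" means these compounds.

Compound 1 `CONC(=O)c1ccccc1` was tested in an ADME assay on Huh-7 cells (Homo sapiens) for cytotoxicity, read by MTT assay, with a stated time of 72 h (on this read-out higher numbers stand for lower toxicity in this test and lower numbers for higher toxicity in this test), and gave only a limit, > 800000 nM. Compound 2 `CONC(=O)c1ccccc1O` likewise reached only a limit in this assay, > 800000 nM. The two differ by hydroxy in place of hydrogen on an aromatic carbon, and the step that the two limits leave unreadable from compound 1 to compound 2 is unreadable because of the limit of > 800000 nM in this assay, at which 2 of the 3 values shown sit. Compound 3 `O=C(NO)c1cccc([N+](=O)[O-])c1` gives 160000 nM in this assay; the difference between its core and that of compound 1 is not broken down here. Compound 4 `O=C(NO)c1cc([N+](=O)[O-])ccc1O` awaits measurement and differs from compound 3 by hydroxy in place of hydrogen on an aromatic carbon, the same kind of change as from compound 1 to compound 2, though here the entering group sits ortho to a hydroxycarbamoyl group and para to a nitro group rather than ortro to a group of 5 heavy atoms. The step of a 1.3-fold higher number from compound 3 to compound 4 (0.10 log units; within the scatter) is expected to be small, since the step that the two limits leave unreadable from compound 1 to compound 2 gave no readable size. Compound 4 is estimated at 200000 nM.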

Compound 4, half-maximal cytotoxic concentration: > 1000000 nM
Compound 4: no number, only a limit; the forecaster's own chance of this, stated with the estimate: 25%; at least 5.0-fold (0.69 log units) between middle value and limit.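

On the core of compound 3, hydroxy in place of hydrogen on an aromatic carbon gives an at least 6.2-fold higher number from compound 3 to compound 4 (0.79 log units; beyond the scatter) in this assay. Compound 4 reaches only a limit, > 1000000 nM, so this step has a lower bound and no full size. The same change on the core of compound 1 cannot be read, so the compounds shown do not establish that its effect carries from one core to the other, because both values there are limits: the limit of > 800000 nM in this assay, at which 2 of the 4 values shown sit.

From the compounds shown here alone, it remains open whether an amine or a methoxy group entering at that aromatic carbon would give a step like that of hydroxy. Going by these compounds, it also remains open how the step would look on a core carrying a carboxylic acid in place of the hydroxycarbamoyl group.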